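Chloro for Bromo on the Para Position of Compound 3

A few compounds are considered here, and "the series" means these few. Any claim that something is new, unique, unknown or untested is made for them only; others in the source may bear on it.

All numbers here come from a functional assay on OVCAR-3 cells (Homo sapiens) for inhibition, with a stated time of 48 h; on this read-out higher numbers stand for weaker inhibition of growth and lower numbers for stronger inhibition of growth. Compound 1 `O=C(Nc1sc2c(c1C(=O)NNc1ccccc1)CCCCC2)NS(=O)(=O)c1ccccc1` gives 15200 nM. Compound 2 `CN1CCN(C(=O)c2c(NC(=O)NS(=O)(=O)c3ccccc3)sc3c2CCCCC3)CC1` gives only a limit of the assay, > 100000 nM. Compound 3 `O=C(Nc1sc2c(c1C(=O)NNc1ccc(Br)cc1)CCCCC2)NS(=O)(=O)c1ccccc1` gives 14800 nM.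

Compound 3 thus has the lowest of the two numbers actually measured, but its neighbour compound 1 sits within the scatter of repeated measurements, so the two cannot be told apart; the remaining value is a limit (the limit of > 100000 nM in this assay, at which 1 of the 3 values shown sits). The step from compound 1 to compound 3 adds a bromo group and changes nothing beyond the scatter a 1.0-fold lower number from compound 1 to compound 3 (0.01 log units; within the scatter). The larger steps, an at least 6.5-fold higher number from compound 1 to compound 2 (0.81 log units; beyond the scatter) and an at least 6.7-fold lower number from compound 2 to compound 3 (0.82 log units; beyond the scatter), concern the exchange of the whole group on the carbonyl carbon and do not touch the halogen.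

Compound 4 `O=C(Nc1sc2c(c1C(=O)NNc1ccc(Cl)cc1)CCCCC2)NS(=O)(=O)c1ccccc1` differs from compound 3 only in that halogen: chloro in place of bromo on an aromatic carbon. Since the bromo group itself made no difference that could be seen, as a 1.0-fold lower number from compound 1 to compound 3 (0.01 log units; within the scatter) shows, a swap to chloro at the same place is expected to stay within the scatter. For compound 4 the expected step is a 1.0-fold higher number from compound 3 to compound 4 (0.01 log units; within the scatter). The estimate for compound 4 in this assay is therefore 15000 nM, between 7500 nM and 30000 nM.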

Compound 4, concentration for 50% growth inhibition: > 100000 nM
Compound 4: a limit, no number (the forecaster's own chance of this, stated with the estimate: 5%); at least 6.6-fold (0.82 log units) between middle value and limit.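

Hydrogen and bromo on this aromatic carbon, para to a large group, could not be told apart, so the place looked free to change. Chloro at the same carbon shows that it is not, with an at least 6.7-fold higher number from compound 3 to compound 4 (0.82 log units; beyond the scatter) and, set against the bare ring, an at least 6.5-fold higher number from compound 1 to compound 4 (0.81 log units; beyond the scatter); one halogen atom exchanged for another here reaches as far as the exchange of the whole group on the carbonyl carbon in an at least 6.5-fold higher number from compound 1 to compound 2 (0.81 log units; beyond the scatter). In this assay compound 4 gives > 100000 nM, which is a limit of the assay and not a number, so the steps to it have a floor but no known size: the limit of > 100000 nM in this assay, at which 2 of the 4 values shown sit.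

Going by these compounds, the step between compound 2 and compound 4 cannot be read, with a limit at both ends, and how far compound 4 truly lies from compound 3 stays unknown. Also open, on these data alone, is whether this sharp drop belongs to chloro alone or would also appear with fluoro, methyl or methoxy on the same carbon, and why bromo and chloro part ways here.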